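Working notes: longer straight chain in place of isopropyl

The compounds below may be only part of what the source reports. "The series", "measured", "known", "first", "only" and "open" are said of these compounds alone.

Three compounds of the series have numbers in a functional assay on SW1573 cells (Homo sapiens) for antiproliferative activity, read by sulforhodamine B assay, with a stated time of 48 h; on this read-out higher numbers stand for weaker inhibition of growth and lower numbers for stronger inhibition of growth. Compound 1 `CCCC(C#CC(=O)OC)O/C=C/C(=O)OC` gives 320 nM. Compound 2 `COC(=O)C#CC(CC(C)C)O/C=C/C(=O)OC` gives 380 nM. Compound 3 `COC(=O)C#CC(O/C=C/C(=O)OC)C(C)C` gives 750 nM, the highest of the three: the gap to it from the nearest, a 2.0-fold higher number from compound 2 to compound 3 (0.30 log units; within the scatter), is within the scatter, while the gap from the furthest, a 2.3-fold higher number from compound 1 to compound 3 (0.37 log units; beyond the scatter), is beyond it. The remaining pair moved by a 1.2-fold higher number from compound 1 to compound 2 (0.07 log units; within the scatter).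

Compound 4 `CCCCCC(C#CC(=O)OC)O/C=C/C(=O)OC` differs from compound 3 by pentyl in place of isopropyl on a saturated chain carbon bound to an oxygen on an unsaturated carbon and a triple-bonded carbon. Going by the values given here, the steps that bear on this are the two that introduced isopropyl onto the same saturated chain carbon: from compound 1 by a 2.3-fold higher number from compound 1 to compound 3 (0.37 log units; beyond the scatter) and from compound 2 by a 2.0-fold higher number from compound 2 to compound 3 (0.30 log units; within the scatter). Both raised the number, so removing isopropyl in favour of a straight chain is expected to lower it by a modest amount, roughly reversing those steps. Among the compounds with values here, no measured compound carries a chain as long as pentyl, so the added length is not covered by the series and widens the range. Compound 4 is therefore expected near 350 nM, between 150 nM and 800 nM, which is an expected step of a 2.1-fold lower number from compound 3 to compound 4 (0.33 log units; beyond the scatter).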

Compound 4, concentration for 50% growth inhibition: 1700 nM
Compound 4: middle estimate off by 4.9-fold (0.69 log units), on the low side; the whole stated range lies below it.
By their numbers in this assay, from the lowest: compounds 1, 2 and 3 (each within the scatter of the next, the first and the last beyond it); then compound 4.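

In this assay, pentyl in place of isopropyl on this saturated chain carbon raises the number (a 2.3-fold higher number from compound 3 to compound 4 (0.36 log units; beyond the scatter)), so replacing the branched group with a straight chain does not by itself lower it. The propyl and isobutyl compounds also stand well under the pentyl compound (a 4.5-fold higher number from compound 2 to compound 4 (0.65 log units; beyond the scatter); a 5.3-fold higher number from compound 1 to compound 4 (0.73 log units; beyond the scatter)), making compound 4 the weakest of the four and showing that chain size at this place does not follow one simple trend. Nothing measured here explains the rise with pentyl.

Open questions are whether a butyl chain at this carbon behaves like propyl or like pentyl, and whether a longer chain such as heptyl raises the number further. On these data alone, the effect of a cyclohexyl or phenyl group, or of a chain ending in an amine, at this place also remains open.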